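Shortening the amide chain on a 5-HT1F ligand

The compounds below may be only part of what the source reports. "The series", "measured", "known", "first", "only" and "open" are said of these compounds alone.

Measured compounds in an assay for binding affinity to 5-hydroxytryptamine receptor 1F (Homo sapiens), read by radioligand binding; on this read-out higher numbers stand for weaker inhibition and lower numbers for stronger inhibition:
- Compound 1 `CN1CCC(c2c[nH]c3cnc(NC(=O)c4ccc(F)cc4)cc23)CC1`: compound 1 gives 13 nM
- Compound 2 `COc1ccccc1C(=O)Nc1ccc2[nH]cc(C3CCN(C)CC3)c2n1`: compound 2 gives 20 nM
- Compound 3 `CN1CCC(c2c[nH]c3ccc(NC(=O)C4CCCCC4)nc23)CC1`: compound 3 gives 20 nM

All three share a core with a methylpiperidine and an amide, and differ only in the group on the amide carbonyl. Compound 3 matches compound 2 at the digits shown, and compound 1 differs from both by less than the usual scatter. Within the data shown here, the one measured step that bears on the amide group, no change at the digits printed from compound 2 to compound 3 (within the scatter), shows the carbonyl tolerating a cyclohexyl in place of an aromatic ring.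

Compound 4 `CCCC(=O)Nc1ccc2[nH]cc(C3CCN(C)CC3)c2n1` is not yet measured. Its change from compound 3 is propyl in place of cyclohexyl on a carbonyl carbon. Among the measured compounds shown here, no measured step tests a chain this short, so the expectation rests on the unchanged step from compound 2 to compound 3 and on the smaller size of what enters. Compound 4 is therefore expected to show a modest rise, a 2.0-fold higher number from compound 3 to compound 4 (0.30 log units; within the scatter), with a wide range, giving an estimated 40 nM (from 10 nM to 160 nM).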

Compound 4, inhibition constant: 6.9 nM
For compound 4 the middle estimate is 5.8-fold (0.76 log units) above the measured one; the whole stated range lies above it.
By their numbers in this assay, from the lowest: compounds 4, 1, 2 and 3 (each within the scatter of the next, the first and the last beyond it).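

Among these compounds, at this carbonyl carbon, propyl in place of cyclohexyl gives a 2.9-fold lower number from compound 3 to compound 4 (0.46 log units; beyond the scatter) in this assay and is the first change here that lies beyond the scatter. Propyl in place of 2-methoxyphenyl gives a 2.9-fold lower number from compound 2 to compound 4 (0.46 log units; beyond the scatter) and shows, for these compounds, that a ring on the carbonyl is not needed for this level of binding. Nothing available accounts for the lower number.

From the compounds shown here alone, whether a smaller group such as methyl or a longer chain such as pentyl would lower the number further remains open. So does the effect of an amine on the chain.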